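This account rests on a few compounds, and the source may have more. Where it says the series, first, only, none or still open, it means among the compounds named here.

Measured in a functional assay on M21 cells (Homo sapiens) for antiproliferative activity, read by sulforhodamine B assay, with a stated time of 48 h; on this read-out lower numbers stand for stronger inhibition and higher numbers for weaker inhibition:
compound 1 `CCN1CCN(c2ccc(S(=O)(=O)Oc3cccc(OC)c3)cc2)C1=O`: 7000 nM
compound 2 `CCN1CCN(c2ccc(S(=O)(=O)Oc3cccc(I)c3)cc2)C1=O`: 2200 nM

Of these two compounds, compound 2 has the lower number, at 2200 nM, while compound 1 stands at 7000 nM. The next compound, compound 3 `CCN1CCN(c2ccc(S(=O)(=O)Oc3ccc(OC)cc3)cc2)C1=O`, keeps the shared core and changes only the aryl group on the sulfonate oxygen, with 4-methoxyphenyl in place of 3-iodophenyl on an oxygen whose other neighbour is the sulfonyl sulfur: 4-methoxyphenyl in place of 3-iodophenyl on an oxygen.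

Within the data shown here, only one measured step bears on this change, the modest 3.2-fold lower number from compound 1 to compound 2 (0.50 log units; beyond the scatter), where iodo took the place of methoxy on an aromatic carbon. Compound 3 returns to a methoxy group, which points to a higher number in this assay, of similar or slightly smaller size than that step. Among the measured compounds shown here, no measured compound carries the 4-methoxyphenyl group, so this expectation remains uncertain. The expected change is a 2.3-fold higher number from compound 2 to compound 3 (0.36 log units; beyond the scatter). Compound 3 is estimated at 5000 nM, with an expected range of 1600 nM to 16000 nM.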

Compound 3, half-maximal inhibitory concentration: 26000 nM
Compound 3: the middle estimate sits 5.2-fold (0.72 log units) below what was measured; the measured number lies above the stated range.
By their numbers in this assay, from the lowest: compound 2; then compound 1; then compound 3.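

In this assay the aryl group on the oxygen whose other neighbour is the sulfonyl sulfur turns out to matter more than the earlier pair could show, since 4-methoxyphenyl in place of 3-iodophenyl gives a 12-fold higher number from compound 2 to compound 3 (1.07 log units; beyond the scatter) and is a large step where the earlier one was modest. The same methoxy group also gives different numbers in its two named placements, as 4-methoxyphenyl in place of 3-methoxyphenyl gives a 3.7-fold higher number from compound 1 to compound 3 (0.57 log units; beyond the scatter) and so shows that the result at this position depends on where the substituent sits on the phenyl ring and not only on which substituent it is. Nothing measured here accounts for either step.

The three compounds leave open whether 4-iodophenyl would follow the same trend as the methoxy pair, so the effects of the iodo group and of its placement remain unseparated. They also leave open how a 3-aminophenyl group, a 3-carboxyphenyl group or a longer chain such as 3-butoxyphenyl would fare on this oxygen with the shared core unchanged.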